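The source may report more compounds than this note shows. Statements on the series, on what has been measured and on what is new or still open speak of the compounds shown alone.

Among the measured compounds shown here, in a functional assay on A549 cells (Homo sapiens) for inhibition, read by MTT assay, with a stated time of 48 h (on this read-out higher numbers stand for weaker inhibition and lower numbers for stronger inhibition), compound 1 `COc1ccc(N(C)c2nc(C)nc3ccccc23)cc1OCCCCCC[Se]C#N` gives 5520 nM, the highest of the three numbers measured so far. Compound 2 `Cc1nc(N(C)c2ccc([Se]C#N)c(C)c2)c2ccccc2n1` gives 8 nM, and compound 3 `Cc1nc(N(C)c2ccc(OCC[Se]C#N)cc2)c2ccccc2n1` gives 893 nM; both of these sit below compound 1 by gaps beyond the scatter, with compound 2 the furthest away. Every measured compound contains a selenium atom. Compound 4 `COc1ccc(N(C)c2nc(C)nc3ccccc23)cc1OCCN` differs from compound 1 by one nitrogen atom in place of a group of 7 heavy atoms (5 carbon, 1 nitrogen, 1 selenium; no ring), on a saturated chain carbon, two bonds along the chain from an oxygen on an aromatic ring. For the measured compounds named here, no measured pair shows this change, so its effect cannot be read from the data; what remains once the selenium is gone has not been tested. The expected step, toward weaker inhibition, is a 2.7-fold higher number from compound 1 to compound 4 (0.43 log units; beyond the scatter). Compound 4 is therefore estimated at 15000 nM, within a range from 4000 nM to 60000 nM.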

Compound 4, half-maximal inhibitory concentration: 122 nM
For compound 4 the middle estimate is 120-fold (2.09 log units) above the measured one, outside the stated range (below it).
By their numbers in this assay, from the lowest: compound 2; then compound 4; then compound 3; then compound 1.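

At this saturated chain carbon, putting amino in place of the selenium-bearing group gives a 45-fold lower number from compound 1 to compound 4 (1.66 log units; beyond the scatter) in this assay, a large step toward stronger inhibition. Among the compounds shown here, on this core, then, selenium is not needed for inhibition in the nanomolar range, something the earlier compounds, all containing selenium, could not show. No measured evidence accounts for the step. Still open, as far as these compounds go, is whether the amino group itself or the shorter chain carries this step. A longer chain ending in an amine, or a carboxylic acid in place of the amino group, would help separate the two.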